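Replacing a Methoxyphenyl Group: What to Expect

This account rests on a few compounds, and the source may have more. Where it says the series, first, only, none or still open, it means among the compounds named here.

Of the compounds shown here, two sharing one core have been measured so far in a functional assay on PC-12 cells (Rattus norvegicus) for cytotoxicity, read by MTT assay, with a stated time of 24 h; a lower number here means that less compound is needed, a higher number that more compound is needed for the effect. In it, compound 1 `COc1ccc(N2CCN(CC#CCOC(=O)c3sc4ncnc(N5CCCCC5)c4c3C)CC2)cc1` gives 35.3 ug/mL, and compound 2 `COc1cccc(N2CCN(CC#CCOC(=O)c3sc4ncnc(N5CCCCC5)c4c3C)CC2)c1` gives 40.4 ug/mL. Within the data shown here, the only measured step is a 1.1-fold higher number from compound 1 to compound 2 (0.06 log units; within the scatter), so compound 2 stands level with compound 1, and the two cannot be ranked.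

Compound 3 `Cc1ccc(C#N)c(N2CCN(CC#CCOC(=O)c3sc4ncnc(N5CCCCC5)c4c3C)CC2)c1` has not been measured yet. It carries 2-cyano-5-methylphenyl in place of 3-methoxyphenyl on an amine nitrogen in a ring, a change counted as 2-cyano-5-methylphenyl in place of 3-methoxyphenyl on an amine nitrogen in a ring. Among the measured compounds shown here, the one measured step bears on this change only loosely. For the measured compounds named here, it moved a methoxy group to another place on the phenyl ring, and no measured compound carries a nitrile. It is therefore a weak guide, and nothing in the data points to a direction. The expected outcome in this assay is no step beyond the scatter, and the estimated step is a 1.1-fold lower number from compound 2 to compound 3 (0.03 log units; within the scatter). For compound 3 the expected value is 38 ug/mL, with an estimated range from 18 ug/mL to 80 ug/mL.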

Compound 3, half-maximal effective concentration: 38.2 ug/mL
Compound 3: the middle estimate sits 1.0-fold (0.00 log units) below what was measured; low and high end bracket the measured number.
By their numbers in this assay, from the lowest: compounds 1, 3 and 2 (each within the scatter of the next).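

In this assay, putting 2-cyano-5-methylphenyl in place of 3-methoxyphenyl gives a 1.1-fold lower number from compound 2 to compound 3 (0.02 log units; within the scatter), and putting it in place of 4-methoxyphenyl gives a 1.1-fold higher number from compound 1 to compound 3 (0.03 log units; within the scatter). Among these compounds, the earlier pair showed only that a methoxy group can sit at either of two places on the phenyl ring with the numbers staying level; these steps show that the same holds for a phenyl ring with a nitrile and a methyl group and no methoxy group at all, so all three compounds stand level at this position on the amine nitrogen. No measurement at hand explains why the numbers stay level, and none shows whether these groups have any part in the effect read here.

As far as these compounds go, all three compounds keep a substituted phenyl ring at this position, so it remains open whether a benzyl group, a pyridine ring or a phenyl ring bearing a carboxylic acid would also stay level or would give a step beyond the scatter. The shared core is the same throughout, so these numbers also say nothing about changes made elsewhere in the molecule.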